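The compounds below may be only part of what the source reports. "The series", "measured", "known", "first", "only" and "open" are said of these compounds alone.

In an assay on Sf9 cells for inhibition of serine/threonine-protein kinase 4 (Homo sapiens), read by luminescence and ADP-Glo, with a stated time of 1 h, in the presence of a further agent that is not named here (on this read-out higher numbers stand for weaker inhibition and lower numbers for stronger inhibition), the three measured compounds sit close together. Compound 1, `CN1C(=O)C(C2CC2)N(C)c2nc(Nc3ccc(S(N)(=O)=O)cc3)ncc21`, gives 136 nM; compound 2, `CCCC1C(=O)N(C)c2cnc(Nc3ccc(S(N)(=O)=O)cc3)nc2N1C`, gives 206 nM; and compound 3, `CC(C)CC1C(=O)N(C)c2cnc(Nc3ccc(S(N)(=O)=O)cc3)nc2N1C`, gives 77 nM. Compound 2 thus stands at the highest number of the three, though the step of a 1.5-fold higher number from compound 1 to compound 2 (0.18 log units; within the scatter) is within the scatter, while its gap to compound 3 is a 2.7-fold lower number from compound 2 to compound 3 (0.43 log units; beyond the scatter), a modest change that lies beyond it.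

Compound 4, `CCc1ccccc1C1C(=O)N(C)c2cnc(Nc3ccc(S(N)(=O)=O)cc3)nc2N1C`, is not yet measured. It differs from compound 2 in one place: 2-ethylphenyl in place of propyl on a saturated ring carbon.

Among the compounds with values here, two measured steps bear on this. The step of a 1.5-fold higher number from compound 1 to compound 2 (0.18 log units; within the scatter) shows that exchanging cyclopropyl for propyl on this saturated ring carbon leaves the number essentially where it was; the step of a 2.7-fold lower number from compound 2 to compound 3 (0.43 log units; beyond the scatter) shows that a larger saturated group at the same carbon gives a modestly lower number. Within the data shown here, neither step introduces an aromatic ring, and nothing among the measured compounds tells how an eight-heavy-atom group of that kind will behave here, so the expectation rests on the direction seen in compound 3 alone and carries a wide range.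

Compound 4 is therefore estimated at 110 nM, within 30 nM to 400 nM, corresponding to an expected step of a 1.9-fold lower number from compound 2 to compound 4 (0.27 log units; within the scatter).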

Compound 4, half-maximal inhibitory concentration: 51 nM
Beside the measured number, compound 4's estimate is 2.2-fold (0.33 log units) above it, and the stated range covers the measured number.
By their numbers in this assay, from the lowest: compounds 4, 3, 1 and 2 (each within the scatter of the next, the first and the last beyond it).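

In this assay, within the data shown here, the saturated ring carbon now carries an aromatic group for the first time, and 2-ethylphenyl, with its one six-membered aromatic ring of carbon only, is tolerated there, giving a 4.0-fold lower number from compound 2 to compound 4 (0.61 log units; beyond the scatter) and a 2.7-fold lower number from compound 1 to compound 4 (0.43 log units; beyond the scatter), both modest steps beyond the scatter. Against the branched saturated chain of compound 3, the exchange gives a 1.5-fold lower number from compound 3 to compound 4 (0.18 log units; within the scatter), so on this read-out isobutyl and 2-ethylphenyl cannot be told apart, and a saturated chain and an aromatic ring both remain compatible with this carbon. No measurement is at hand that would explain these steps.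

On these data alone, how a plain phenyl would compare with 2-ethylphenyl remains open, so the part played by the ethyl group on the ring cannot be separated from that of the ring itself. All four groups at this carbon consist of carbon only, which leaves open how the number would respond to a group bearing an amine, a hydroxyl or a carboxylic acid, or to a pyridine ring in place of the benzene ring.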